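The compounds below may be only part of what the source reports. "The series", "measured", "known", "first", "only" and "open" are said of these compounds alone.

Compound 1 `c1ccc(-c2ccc3c(NCCCNCc4ccco4)ccnc3c2)cc1`, compound 2 `Fc1ccc(Cc2ccc3c(NCCCNCc4ccco4)ccnc3c2)c(Cl)c1` and compound 3 `c1ccc(CCc2ccc3c(NCCCNCc4ccco4)ccnc3c2)cc1` share one core and differ only in the group on an aromatic carbon. In a physicochemical assay for acid dissociation, compound 1 gives 9.47, compound 2 gives 9.47 and compound 3 gives 9.47; compound 3 stands level with both at the digits shown. The steps of no change at the digits printed from compound 1 to compound 2 (within the scatter), no change at the digits printed from compound 1 to compound 3 (within the scatter) and no change at the digits printed from compound 2 to compound 3 (within the scatter) all stay within the scatter, so three different groups at that carbon have given the same read-out. Compound 4 `c1coc(CNCCCNc2ccnc3cc(CC4CCCCC4)ccc23)c1` differs from compound 3 by cyclohexyl in place of benzyl on a saturated chain carbon bound to an aromatic carbon. The step from compound 2 to compound 3 bears most directly, an exchange on the same saturated chain carbon, and showed nothing beyond the scatter; no step beyond the scatter is therefore expected here either. Compound 4 is estimated at 9.47, range 9.2 to 9.75. The expected step is no change at the digits printed from compound 3 to compound 4 (within the scatter).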

Compound 4, acid dissociation constant: 9.47
Beside the measured number, compound 4's estimate shows no gap at the digits printed, within the range that was stated.
By their numbers in this assay, from the lowest: compounds 1, 2, 3 and 4 (each within the scatter of the next).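

Cyclohexyl in place of benzyl on a saturated chain carbon bound to an aromatic carbon gives no change at the digits printed from compound 3 to compound 4 (within the scatter) in this assay, and cyclohexyl is the only non-aromatic ring in this group among the compounds shown. Cyclohexyl in place of 2-chloro-4-fluorophenyl gives no change at the digits printed from compound 2 to compound 4 (within the scatter), and the remaining step is no change at the digits printed from compound 1 to compound 4 (within the scatter), so aromatic and non-aromatic rings read alike across these four compounds. No supporting data bear on why the read-out holds.

Open, on these data alone, is whether an amine or a carboxylic acid on this group, or a longer chain at the same aromatic carbon, would move the read-out in this assay beyond the scatter.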